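Swapping the Halophenyl on a Triazole-Linked Spiro Scaffold

A few compounds are considered here, and "the series" means these few. Any claim that something is new, unique, unknown or untested is made for them only; others in the source may bear on it.

Compound 1 `Cc1cccc(-n2nncc2CN2C(=O)C3(C(C#N)=C(N)Oc4c3c3nc5ccccc5nc3c3ccccc43)c3ccccc32)c1` and compound 2 `N#CC1=C(N)Oc2c(c3nc4ccccc4nc3c3ccccc23)C12C(=O)N(Cc1cnnn1-c1cccc(Cl)c1)c1ccccc12` share the same large spiro core and differ only in that compound 2 carries chloro in place of methyl on an aromatic carbon. In a functional assay on HepG2 cells (Homo sapiens) for antiproliferative activity, read by MTT assay, with a stated time of 48 h (a lower number here means a stronger inhibitor, a higher number a weaker inhibitor), compound 1 gives only a limit of the assay, > 50000 nM. In this assay compound 2 likewise gives only a limit, > 50000 nM. The step that the two limits leave unreadable from compound 1 to compound 2 therefore cannot be read, because both values sit at the limit of > 50000 nM in this assay, at which 2 of the 2 values shown sit.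

Compound 3 `N#CC1=C(N)Oc2c(c3nc4ccccc4nc3c3ccccc23)C12C(=O)N(Cc1cnnn1-c1ccccc1Br)c1ccccc12` differs from compound 2 by 2-bromophenyl in place of 3-chlorophenyl on an aromatic nitrogen. For the measured compounds named here, no measured step bears directly on this change, and the single measured step is itself unreadable. With both neighbours at the limit, compound 3 is expected to move no more than the scatter, a step that the limit leaves unreadable from compound 2 to compound 3. Compound 3 is thus estimated at 60000 nM, between 20000 nM and 200000 nM, most probably reported again only as a limit.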

Compound 3, half-maximal inhibitory concentration: > 50000 nM
Compound 3 gave a limit, no number; the forecaster's own chance of this, stated with the estimate: 85%; the middle value does not contradict the limit.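

In this assay compound 3 joins compound 1 and compound 2 in giving only a limit, so no step among these three compounds can be read: (the limit of > 50000 nM in this assay, at which 3 of the 3 values shown sit).

The compounds shown leave open which change to the shared core, if any, would give a measurable value rather than a limit.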